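This account rests on a few compounds, and the source may have more. Where it says the series, first, only, none or still open, it means among the compounds named here.

Of the compounds shown here, three of one series have been measured in a functional assay on OVCAR-3 cells (Homo sapiens) for antiproliferative activity, read by MTT assay, with a stated time of 24 h; a higher number here means a weaker inhibitor, a lower number a stronger inhibitor. Compound 1 `O=C(NNc1ccccc1F)c1ccc(NS(=O)(=O)c2cnc(O)nc2O)cc1` carries a 2-fluorophenyl group on an amine nitrogen. In this assay compound 1 returns only a limit, > 20000 nM. Compound 2 `O=C(NNc1ccc(F)cc1)c1ccc(NS(=O)(=O)c2cnc(O)nc2O)cc1` differs from compound 1 by 4-fluorophenyl in place of 2-fluorophenyl on an amine nitrogen. In this assay compound 2 likewise returns only a limit, > 20000 nM. The step is a step that the two limits leave unreadable from compound 1 to compound 2, because the limit of > 20000 nM in this assay, at which 2 of the 3 values shown sit, holds both of these values.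

Compound 3 `O=C(NNc1ccccc1F)c1cccc(NS(=O)(=O)c2cnc(O)nc2O)c1` has the same atoms as compound 1 joined differently; the difference between the two cores is not broken down here. In this assay, among the compounds with values here, compound 3 gives 17000 nM, the only number among the three. Compound 4 `O=C(NNc1ccc(F)cc1)c1cccc(NS(=O)(=O)c2cnc(O)nc2O)c1` has not yet been measured and differs from compound 3 by 4-fluorophenyl in place of 2-fluorophenyl on an amine nitrogen, the same change as that from compound 1 to compound 2. That earlier step could not be read, so no size carries over. Compound 4 is expected to sit near compound 3, with a step estimated at a 1.2-fold higher number from compound 3 to compound 4 (0.07 log units; within the scatter). This rests on compound 3, whose value 17000 nM is already weak. The estimate for compound 4 is 20000 nM, between 9000 nM and 45000 nM.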

Compound 4, half-maximal inhibitory concentration: > 20000 nM
Compound 4 gave a limit, no number; the forecaster's own chance of this, stated with the estimate: 50%; the middle value lies on the limit itself.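

In this assay compound 4 returns only a limit, > 20000 nM. Placing 4-fluorophenyl in place of 2-fluorophenyl on the amine nitrogen gives an at least 1.1-fold higher number from compound 3 to compound 4 (0.07 log units; that floor lies within the scatter), which shows only a floor for the change on this core and does not show how large the change really is. The same change could not be read on the core of compound 1, so neither step has a size that can be set against the other, and the values show neither that the change carries over from one core to the other nor that it fails to: the limit of > 20000 nM in this assay, at which 3 of the 4 values shown sit.

Still open, from the compounds shown here alone, is whether another group on the amine nitrogen, such as a phenyl ring bearing a carboxylic acid, an amine or a methoxy group, would bring values clear of the limit. Also open, going by these compounds, is what the fluorine swap does on a core where both partners give numbers.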